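Swapping the aryl halide on a shared oxadiazole-bearing core

This account rests on a few compounds, and the source may have more. Where it says the series, first, only, none or still open, it means among the compounds named here.

Measured so far:
- compound 1, `CC(C)(C)n1ncc(OCc2nnc(-c3ccc(Br)cc3)o2)c(Cl)c1=O`: 3.21
- compound 2, `CC(C)(C)n1ncc(OCc2nnc(-c3ccccc3Cl)o2)c(Cl)c1=O`: 3.19
- compound 3, `CC(C)(C)n1ncc(OCc2nnc(-c3c(F)cccc3F)o2)c(Cl)c1=O`: 2.75

In a physicochemical assay for lipophilicity (a lower number here means a more polar compound, a higher number a more lipophilic compound), compound 1 stands highest of the three numbers. Compound 2 sits closest, a number 0.02 log units lower from compound 1 to compound 2 (within the scatter), and compound 3 furthest, a number 0.46 log units lower from compound 1 to compound 3 (beyond the scatter). Compound 4, `CC(C)(C)n1ncc(OCc2nnc(-c3ccccc3F)o2)c(Cl)c1=O`, has not yet been measured. It differs from compound 1 in one place: 2-fluorophenyl in place of 4-bromophenyl on an aromatic carbon. The nearest guides are the two steps out of compound 1: one halogenated phenyl for another changed nothing beyond the scatter, whereas the 2,6-difluorophenyl brought a modest drop. A single fluorine should fall between these, so a small to modest step down is expected, a number 0.36 log units lower from compound 1 to compound 4 (beyond the scatter). Compound 4 is therefore estimated at 2.85, within 2.6 to 3.1.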

Compound 4, partition coefficient: 2.89
Estimate against measurement, compound 4: 0.04 log units below, and the stated range covers the measured number.
By their numbers in this assay, from the lowest: compounds 3, 4, 2 and 1 (each within the scatter of the next, the first and the last beyond it).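

At this aromatic carbon, this assay shows that a single fluorine on the phenyl group is enough for a step beyond the scatter out of compound 1 (a number 0.32 log units lower from compound 1 to compound 4 (beyond the scatter)). The 2-fluorophenyl group cannot be separated from either neighbour (a number 0.30 log units lower from compound 2 to compound 4 (within the scatter); a number 0.14 log units higher from compound 3 to compound 4 (within the scatter)), even though compound 2 and compound 3 lie beyond the scatter of each other. These halogenated phenyl groups therefore form a continuous run of values, not two separate levels. Nothing shown gives a cause for these steps. Going by these compounds, what an amine or a carboxylic acid on this phenyl group would do to the number remains open.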